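Ethyl in place of propyl on the alkyne-linked hydroxyurea

This account rests on a few compounds, and the source may have more. Where it says the series, first, only, none or still open, it means among the compounds named here.

Measured compounds:
compound 1, `CC(C)C(C#Cc1cccc(C(=O)NCc2ccccc2C(F)(F)F)c1)N(O)C(N)=O`, 500 nM
compound 2, `C[C@@H](C#Cc1cccc(C(=O)NCc2ccccc2C(F)(F)F)c1)N(O)C(N)=O`, 700 nM
compound 3, `CCC(C#Cc1cccc(C(=O)NCc2ccccc2C(F)(F)F)c1)N(O)C(N)=O`, 500 nM

All three were tested in an assay for inhibition of Polyunsaturated fatty acid 5-lipoxygenase (Homo sapiens), read by HPLC, with stated times of 15 min and 10 min; a higher number here means a weaker inhibitor, a lower number a stronger inhibitor. Compound 3 stands level with compound 1, the two together giving the lowest numbers of the three, and compound 2 lies only a little higher, within the scatter.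

Compound 4, `C[C@H](C#Cc1cccc(C(=O)NCc2ccccc2C(F)(F)F)c1)N(O)C(N)=O`, differs from compound 3 by 1-(carbamoyl(hydroxy)amino)ethyl in place of 1-(carbamoyl(hydroxy)amino)propyl on a triple-bonded carbon. Compound 2 carries the same 1-(carbamoyl(hydroxy)amino)ethyl group. The bearing steps are a 1.4-fold lower number from compound 2 to compound 3 (0.15 log units; within the scatter) and a 1.4-fold higher number from compound 1 to compound 2 (0.15 log units; within the scatter), both within the scatter. A step of similar small size, towards a slightly higher number or none beyond the scatter, is therefore expected: a 1.4-fold higher number from compound 3 to compound 4 (0.15 log units; within the scatter). Compound 4 is estimated at 700 nM, between 350 nM and 1400 nM.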

Compound 4, half-maximal inhibitory concentration: 600 nM
For compound 4 the middle estimate is 1.2-fold (0.07 log units) above the measured one; low and high end bracket the measured number.
By their numbers in this assay, from the lowest: compounds 1, 3, 4 and 2 (each within the scatter of the next).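

Compound 4 puts the stereocentre at this position to a direct test, and the comparison is a clean one: the fact that compounds 2 and 4 differ only in the configuration as drawn. Reversing that centre gives a 1.2-fold lower number from compound 2 to compound 4 (0.07 log units; within the scatter), so the two drawn configurations cannot be told apart here. The chain length is no more decisive, with a 1.2-fold higher number from compound 3 to compound 4 (0.08 log units; within the scatter) and a 1.2-fold higher number from compound 1 to compound 4 (0.08 log units; within the scatter), so the 1-(carbamoyl(hydroxy)amino)ethyl, propyl and 2-methylpropyl groups all remain within the scatter of one another. Going by these compounds, whether a longer chain such as hexyl, or a phenyl group, would stay within that scatter remains open.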